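Furan-3-yl in place of 4-fluorophenyl: an antiproliferative step

The compounds below may be only part of what the source reports. "The series", "measured", "known", "first", "only" and "open" are said of these compounds alone.

Measured in a functional assay on CAPAN-1 cells (Homo sapiens) for antiproliferative activity, with a stated time of 72 h; a higher number here means a weaker inhibitor, a lower number a stronger inhibitor:
- compound 1 `CCCC#Cc1cc([C@@H]2O[C@H](CO)[C@@H](O)[C@H]2O)n2ncnc(N)c12`: 20 nM
- compound 2 `Nc1ncnn2c([C@@H]3O[C@H](CO)[C@@H](O)[C@H]3O)cc(C#Cc3ccccc3)c12`: 37700 nM
- compound 3 `Nc1ncnn2c([C@@H]3O[C@H](CO)[C@@H](O)[C@H]3O)cc(-c3ccc(F)cc3)c12`: 65600 nM

Compound 3 sits at the weak end of this small set, and it shares that end with one close neighbour. The gap there is a 1.7-fold higher number from compound 2 to compound 3 (0.24 log units; within the scatter). The gap to the other end is far wider, at a 3300-fold higher number from compound 1 to compound 3 (3.52 log units; beyond the scatter).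

Compound 4 `Nc1ncnn2c([C@@H]3O[C@H](CO)[C@@H](O)[C@H]3O)cc(-c3ccoc3)c12` carries furan-3-yl in place of 4-fluorophenyl on an aromatic carbon.

Among the measured compounds shown here, two measured steps bear on this change. The first, a 1.7-fold higher number from compound 2 to compound 3 (0.24 log units; within the scatter), shows that exchanging one aromatic-ring group for another at this place left the number within the scatter. The second, a 3300-fold higher number from compound 1 to compound 3 (3.52 log units; beyond the scatter), shows that this place can also carry a group with a far lower number, as compound 1 does at 20 nM. For the measured compounds named here, no measured compound has a five-membered aromatic ring here, so the data offer no direct guide. A moderate move towards a lower number therefore seems more likely than none, though a result close to compound 3 remains possible.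

The step expected in this assay is a 22-fold lower number from compound 3 to compound 4 (1.34 log units; beyond the scatter), and this estimate is loose. For compound 4 the estimated value is 3000 nM, with an expected range from 100 nM to 80000 nM.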

Compound 4, half-maximal inhibitory concentration: 900 nM
Compound 4: middle estimate off by 3.3-fold (0.52 log units), on the high side, and the stated range covers the measured number.
By their numbers in this assay, from the lowest: compound 1; then compound 4; then compounds 2 and 3 (each within the scatter of the next).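

In this assay, the change from 4-fluorophenyl to furan-3-yl (a 73-fold lower number from compound 3 to compound 4 (1.86 log units; beyond the scatter)) shows that this aromatic carbon does not treat all aromatic-ring groups alike, a difference that the close values of compound 2 and compound 3 did not reveal. The replacement of 2-phenylethynyl by furan-3-yl (a 42-fold lower number from compound 2 to compound 4 (1.62 log units; beyond the scatter)) points the same way, so among the three groups that carry an aromatic ring here, the five-membered ring with one hetero atom gives the lowest number. Even so, furan-3-yl closes only part of the distance to pent-1-yn-1-yl (a 45-fold higher number from compound 1 to compound 4 (1.65 log units; beyond the scatter)), and compound 1 keeps the lowest number of the four.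

No data given here explain why furan-3-yl differs so much from 4-fluorophenyl. Going by these compounds, it also remains open whether the ring oxygen or the ring size matters more, and how thiophen-3-yl, furan-2-yl, or a longer chain such as hex-1-yn-1-yl would behave at this place.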